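Dropping the Methoxy Group from a Porcupine Inhibitor

This account rests on a few compounds, and the source may have more. Where it says the series, first, only, none or still open, it means among the compounds named here.

Three compounds have been measured in an assay on L cells for inhibition of Protein-serine O-palmitoleoyltransferase porcupine (Mus musculus), read by reporter gene assay, with a stated time of 24 h; on this read-out higher numbers stand for an effect only at larger amounts of compound and lower numbers for an effect already at smaller amounts:

Compound 1 `COc1ccc2nc(NC(=O)CNC(=O)c3nn(-c4ccccc4OC)c(=O)c4ccccc34)sc2c1`: 90 nM
Compound 2 `COc1ccc2nc(NC(=O)CSc3nc4c(c(=O)n3-c3ccccc3)SCC4)sc2c1`: 40 nM
Compound 3 `COc1ccc2nc(NC(=O)CNC(=O)c3nn(-c4ccc(F)cc4)c(=O)c4ccccc34)sc2c1`: 90 nM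

Compound 1 stands level with compound 3, and together they give the highest numbers of the three; compound 2 gives a lower number. Among the compounds with values here, the single step between closely related compounds, no change at the digits printed from compound 1 to compound 3 (within the scatter), came with 4-fluorophenyl in place of 2-methoxyphenyl on an aromatic nitrogen, at the opposite end of the molecule.

Compound 4 `COc1ccccc1-n1nc(C(=O)NCC(=O)Nc2nc3ccccc3s2)c2ccccc2c1=O` differs from compound 1 by hydrogen in place of methoxy on an aromatic carbon. Within the data shown here, no measured step touches this end, since all three measured compounds carry the methoxy, so there is no direct guide. The methoxy is shared by every compound with a measured value, and nothing measured speaks to its removal. For compound 4 a modest rise is expected, estimated at 200 nM with a range of 60 nM to 700 nM, corresponding to the expected step of a 2.2-fold higher number from compound 1 to compound 4 (0.35 log units; beyond the scatter).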

Compound 4, half-maximal effective concentration: 10000 nM
Estimate against measurement, compound 4: 50-fold (1.70 log units) below, and the stated range ends below it.
By their numbers in this assay, from the lowest: compound 2; then compounds 1 and 3 (each within the scatter of the next); then compound 4.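

Taking the methoxy off the 6-methoxy-1,3-benzothiazol-2-yl group gives a 110-fold higher number from compound 1 to compound 4 (2.05 log units; beyond the scatter) in this assay, while the change at the opposite end of the molecule gave no change at the digits printed from compound 1 to compound 3 (within the scatter) in the same assay. So in this pair, the methoxy end is far more sensitive to change than the earlier step at the other end could show. Nothing available explains why removing this group has so large an effect.

From the compounds shown here alone, it remains open whether an ethoxy, a chlorine or a hydroxyl on this carbon could take the place of the methoxy. Going by these compounds, whether removing the methoxy from compound 2 would have a similar effect is also open.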